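Moving the chlorine on the benzyloxy group

The source may report more compounds than this note shows. Statements on the series, on what has been measured and on what is new or still open speak of the compounds shown alone.

Compound 1 `COc1cccc(OC)c1OCCNCCOc1ccccc1OCc1ccccc1Cl`: in an assay on CHO cells for displacement of a labelled ligand from Alpha-1B adrenergic receptor (Homo sapiens) (a higher number here means a weaker inhibitor, a lower number a stronger inhibitor), compound 1 gives 0.562 nM.
Compound 2 `COc1cccc(OC)c1OCCNCCOc1ccccc1OCc1cccc(Cl)c1`: in this assay compound 2 gives 0.159 nM.

Compound 2 has the lower of the two numbers; its nearest neighbour is compound 1, and the step of a 3.5-fold lower number from compound 1 to compound 2 (0.55 log units; beyond the scatter) lies beyond the scatter. Compound 3 `COc1cccc(OC)c1OCCNCCOc1ccccc1OCc1ccc(Cl)cc1` differs from compound 2 by 4-chlorophenyl in place of 3-chlorophenyl on a saturated chain carbon bound to an oxygen on an aromatic ring. Going by the values given here, only the step of a 3.5-fold lower number from compound 1 to compound 2 (0.55 log units; beyond the scatter) bears on this change, and it swapped 2-chlorophenyl for 3-chlorophenyl rather than 3-chlorophenyl for 4-chlorophenyl, so it gives no direct guide; no step beyond the scatter, or a modest one in either direction, is expected in this assay. Compound 3 is therefore estimated at 0.25 nM, within 0.08 nM to 0.8 nM, an expected step of a 1.6-fold higher number from compound 2 to compound 3 (0.20 log units; within the scatter).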

Compound 3, inhibition constant: 1 nM
For compound 3 the middle estimate is 4.0-fold (0.60 log units) below the measured one, outside the stated range (above it).
By their numbers in this assay, from the lowest: compound 2; then compounds 1 and 3 (each within the scatter of the next).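

In this assay, 4-chlorophenyl in place of 3-chlorophenyl gives a 6.3-fold higher number from compound 2 to compound 3 (0.80 log units; beyond the scatter), so compound 2 now stands apart from both other chlorine isomers, not only from compound 1. The 2-chlorophenyl and 4-chlorophenyl groups do not separate, with a 1.8-fold higher number from compound 1 to compound 3 (0.25 log units; within the scatter), so only 3-chlorophenyl stands out among the three. Nothing shown here accounts for this.

As far as these compounds go, it remains open whether the result belongs to chlorine itself or would carry over to 3-fluorophenyl or 3-methoxyphenyl. From the compounds shown here alone, how 3,4-dichlorophenyl, which combines the two placements, would compare also stays open.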